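Moving the carboxylic acid along a chain in a receptor-binding series

The compounds below may be only part of what the source reports. "The series", "measured", "known", "first", "only" and "open" are said of these compounds alone.

Three compounds share one core, a pyridinone bearing two phenyl rings on one side and a propyl chain leading to a phenyl ether that carries an acid-bearing group. Compound 1 `O=C(O)COc1cccc(CCCn2cc(C(c3ccccc3)c3ccccc3)ccc2=O)c1` gives 256 nM in an assay on HEK293 cells for displacement of a labelled ligand from chemoattractant receptor-homologous molecule expressed on Th2 cells (Cavia porcellus), read by scintillation counting, with a stated time of 2 h; a lower number here means a stronger inhibitor, a higher number a weaker inhibitor. Compound 2 `O=C(O)COc1cccc(CCCn2cc(C(c3ccc(F)cc3)c3ccc(F)cc3)ccc2=O)c1` gives 359 nM in this assay. Compound 3 `CCC(Oc1cccc(CCCn2cc(C(c3ccccc3)c3ccccc3)ccc2=O)c1)C(=O)O` gives 990 nM in this assay, the highest number of the three and therefore the weakest binder among them.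

Going by the values given here, the only single-change step measured is a 3.9-fold higher number from compound 1 to compound 3 (0.59 log units; beyond the scatter), which shows that branching the chain beside the acid weakened binding. Compound 4 `O=C(O)CCCOc1cccc(CCCn2cc(C(c3ccccc3)c3ccccc3)ccc2=O)c1` differs from compound 3 by 3-carboxypropyl in place of 1-carboxypropyl on an oxygen on an aromatic ring: the same atoms are rearranged so that the acid sits at the end of a straight chain instead of on a branched one. Among the compounds with values here, no measured step covers lengthening the chain itself, but compound 1 with its shorter straight chain gave 256 nM, so removing the branch is expected to help, while the longer chain is untested. Compound 4 is expected to reach 450 nM, within 150 nM to 1300 nM, meaning an estimated step of a 2.2-fold lower number from compound 3 to compound 4 (0.34 log units; beyond the scatter).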

Compound 4, half-maximal inhibitory concentration: 99 nM
Beside the measured number, compound 4's estimate is 4.5-fold (0.66 log units) above it, and the stated range ends above it.
By their numbers in this assay, from the lowest: compound 4; then compounds 1 and 2 (each within the scatter of the next); then compound 3.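

Both changes involve the acid-bearing group on the oxygen on an aromatic ring. With the same atoms joined differently, 3-carboxypropyl in place of 1-carboxypropyl gives a 10-fold lower number from compound 3 to compound 4 (1.00 log units; beyond the scatter) in this assay, so how the chain is arranged matters to binding, not only which atoms it contains. Lengthening the unbranched chain also counts: 2-carboxyethyl in place of carboxy gives a 2.6-fold lower number from compound 1 to compound 4 (0.41 log units; beyond the scatter), which shows that the gain from compound 3 is more than the removal of a branch. Nothing available explains why either change strengthens binding.

Still open, from the compounds shown here alone, is whether a longer chain such as 4-carboxybutyl would strengthen binding further, or whether 2-carboxyethyl on the same oxygen would fall short of compound 4. Also open, going by these compounds, is whether the 3-carboxypropyl chain would have the same effect with the fluorophenyl rings of compound 2.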